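Methyl on the aryl ether of compound 1

A few compounds are considered here, and "the series" means these few. Any claim that something is new, unique, unknown or untested is made for them only; others in the source may bear on it.

Compound 1 `Cc1ccccc1Oc1ccc(CC2SC(=O)NC2=O)cc1` is the lowest of the three numbers in a functional assay for agonist activity at Free fatty acid receptor 1 (Homo sapiens), read by FLIPR, in the presence of a further agent that is not named here (a lower number here means that less compound is needed, a higher number that more compound is needed for the effect), where compound 1 gives 124 nM. Compound 2 `Cc1ccc(Oc2ccc(CC3SC(=O)NC3=O)cc2)nc1` gives 4470 nM and compound 3 `O=C1NC(=O)C(Cc2ccc(OCc3ccccc3)cc2)S1` gives 6180 nM; the step of a 36-fold higher number from compound 1 to compound 2 (1.56 log units; beyond the scatter) and the step of a 50-fold higher number from compound 1 to compound 3 (1.70 log units; beyond the scatter) both show that exchanging the 2-methylphenyl group for another group on that oxygen costs a great deal, while the step of a 1.4-fold higher number from compound 2 to compound 3 (0.14 log units; within the scatter) separates the two replacements by nothing beyond the scatter.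

Compound 4 `Cc1ccc(Oc2ccc(CC3SC(=O)NC3=O)cc2)c(C)c1` keeps the 2-methylphenyl group and changes it only by methyl in place of hydrogen on an aromatic carbon. Among the measured compounds shown here, no measured step adds a methyl to this ring, so the pair closest in kind is compound 1 against compound 4 itself. The two large steps from compound 1 concern the whole group, not a single added carbon, and give no direction for this smaller change. The step of a 1.0-fold lower number from compound 1 to compound 4 (0.01 log units; within the scatter) is therefore expected to stay within the scatter, and compound 4 is estimated at 120 nM, with a range from 40 nM to 400 nM.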

Compound 4, half-maximal effective concentration: 121 nM
Compound 4: middle estimate off by 1.0-fold (0.00 log units), on the low side; the range from low to high includes it.
By their numbers in this assay, from the lowest: compounds 4 and 1 (each within the scatter of the next); then compounds 2 and 3 (each within the scatter of the next).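

In this assay the methyl in place of hydrogen, on an aromatic carbon meta to a methyl group and para to a large group, gives a 1.0-fold lower number from compound 1 to compound 4 (0.01 log units; within the scatter) and so lies within the scatter. The earlier large steps exchanged the whole 2-methylphenyl group on the oxygen, whereas this one keeps that group and shows that at least this aromatic carbon carries one extra methyl with no change beyond the scatter. No independent data bear on this result.

Open, from the compounds shown here alone, is whether this same carbon also tolerates something other than methyl, such as a longer chain, an amine or a carboxylic acid. Equally open, going by these compounds, is whether a methyl on the remaining aromatic carbons of that ring would give a similar number.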